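This account rests on a few compounds, and the source may have more. Where it says the series, first, only, none or still open, it means among the compounds named here.

Measured in a functional assay on U-87MG ATCC cells (Homo sapiens) for cytotoxicity, read by MTT assay, with a stated time of 72 h; a higher number here means a weaker inhibitor, a lower number a stronger inhibitor:
compound 1, `COc1cc2c(Oc3ccc(NC(=O)c4cc(-c5ccccc5)nc5ccc(F)cc45)cc3F)ccnc2cc1OCCCN1CCCCC1`: 690 nM
compound 2, `COc1cccc(-c2cc(C(=O)Nc3ccc(Oc4ccnc5cc(OCCCN6CCCCC6)c(OC)cc45)c(F)c3)c3cc(F)ccc3n2)c1`: 1610 nM
compound 3, `COc1cc2c(Oc3ccc(NC(=O)c4cc(-c5ccc(Cl)cc5Cl)nc5ccc(F)cc45)cc3F)ccnc2cc1OCCCN1CCCCC1`: 1040 nM

Compound 2 gives the highest of the three numbers in this assay; its nearest neighbour is compound 3 (a 1.5-fold lower number from compound 2 to compound 3 (0.19 log units; within the scatter)), whereas a 2.3-fold higher number from compound 1 to compound 2 (0.37 log units; beyond the scatter) lies beyond the scatter. Compound 4, `COc1cccc(-c2cc(C(=O)Nc3ccc(Oc4ccnc5cc(OCCCN6CCC(C)CC6)c(OC)cc45)c(F)c3)c3cc(F)ccc3n2)c1`, differs from compound 2 only at the piperidin-1-yl group: methyl in place of hydrogen on a saturated ring carbon. Among the compounds with values here, all three measured steps, a 2.3-fold higher number from compound 1 to compound 2 (0.37 log units; beyond the scatter), a 1.5-fold higher number from compound 1 to compound 3 (0.18 log units; within the scatter) and a 1.5-fold lower number from compound 2 to compound 3 (0.19 log units; within the scatter), vary the aryl substituent on the shared core; none touches the saturated ring, so no measured step speaks to this change. For compound 4 a step within the scatter is therefore expected, a 1.0-fold lower number from compound 2 to compound 4 (0.00 log units; within the scatter). The estimate for compound 4 in this assay is 1600 nM, with a range of 700 nM to 3600 nM.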

Compound 4, half-maximal inhibitory concentration: 840 nM
Compound 4: the middle estimate sits 1.9-fold (0.28 log units) above what was measured, within the range that was stated.
By their numbers in this assay, from the lowest: compounds 1, 4, 3 and 2 (each within the scatter of the next, the first and the last beyond it).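

In this assay, within the data shown here, the first step at the saturated ring, piperidin-1-yl to 4-methylpiperidin-1-yl, is a 1.9-fold lower number from compound 2 to compound 4 (0.28 log units; within the scatter). The earlier steps shown here varied only the aryl substituent, whereas this one shows that methyl in place of hydrogen, three ring bonds from the ring nitrogen, gives no difference that can be told from the scatter in the compound 2 setting. That reading holds for this one pair only.

From the compounds shown here alone, whether a hydroxyl, a carboxylic acid or a longer chain on that ring carbon would behave alike remains open, as does the same methyl on the phenyl compound 1. Nothing available explains the result or bears on it.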